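Replacing the naphthalen-1-yl group of compound 2

The compounds below may be only part of what the source reports. "The series", "measured", "known", "first", "only" and "open" are said of these compounds alone.

In a functional assay on MDA-MB-436 cells (Homo sapiens) for antiproliferative activity, read by MTT assay, with a stated time of 48 h (on this read-out lower numbers stand for stronger inhibition and higher numbers for weaker inhibition), compound 1 `C=CS(=O)(=O)N1CCN(c2ccn3ncc(-c4ccccc4)c3n2)CC1` gives 19500 nM and compound 2 `C=CS(=O)(=O)N1CCN(c2ncnc3sc(-c4cccc5ccccc45)cc23)CC1` gives 28100 nM, two values within the usual scatter of each other. Compound 3 `C=CS(=O)(=O)N1CCN(c2ncnc3sc(-c4ccc(F)nc4)cc23)CC1` carries 6-fluoropyridin-3-yl in place of naphthalen-1-yl on an aromatic carbon, next to the ring sulfur of compound 2 (6-fluoropyridin-3-yl in place of naphthalen-1-yl on an aromatic carbon). Within the data shown here, no measured pair of compounds shows this change, so any forecast is loose. The expected change is a 1.8-fold lower number from compound 2 to compound 3 (0.24 log units; within the scatter), a slight move towards a lower number and no step beyond the scatter. For compound 3 the estimated value is 16000 nM, with a range of 6000 nM to 40000 nM.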

Compound 3, half-maximal inhibitory concentration: 17500 nM
For compound 3 the middle estimate is 1.1-fold (0.04 log units) below the measured one; the measured number falls inside the stated range.
By their numbers in this assay, from the lowest: compounds 3, 1 and 2 (each within the scatter of the next).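

Putting 6-fluoropyridin-3-yl in place of naphthalen-1-yl on this aromatic carbon, next to the ring sulfur, gives a 1.6-fold lower number from compound 2 to compound 3 (0.21 log units; within the scatter) in this assay. So this position tolerates the loss of one of the two aromatic rings and the arrival of a ring nitrogen and a fluorine without a step beyond the scatter. No measurement here gives a reason for this result. On these data alone, what remains open is whether an amine, a carboxylic acid or a longer chain at this position would move the number beyond the scatter.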